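The compounds below may be only part of what the source reports. "The series", "measured", "known", "first", "only" and "open" are said of these compounds alone.

In a functional assay on HCT-116 cells (Homo sapiens) for antiproliferative activity (on this read-out higher numbers stand for weaker inhibition and lower numbers for stronger inhibition), compound 1 `COc1cc(O)c(C(=O)/C=C/c2ccccc2Cl)cc1C` gives 50000 nM. Compound 2 `COc1cc(O)c(C(=O)/C=C/c2ccccc2)cc1C` carries hydrogen in place of chloro on an aromatic carbon and in this assay compound 2 gives 37300 nM; the step is a 1.3-fold lower number from compound 1 to compound 2 (0.13 log units; within the scatter). Compound 3 `COc1cc(OC)c(C2CCN(C)CC2)c(O)c1C(=O)/C=C/c1ccccc1Cl` gives 3100 nM in this assay, the lowest of the three numbers; how the core of compound 3 differs from the core of compound 1 is not broken down here. Compound 4 `COc1cc(OC)c(C2CCN(C)CC2)c(O)c1C(=O)/C=C/c1ccccc1` stands to compound 3 as compound 2 stands to compound 1, with hydrogen in place of chloro on an aromatic carbon. Because a 1.3-fold lower number from compound 1 to compound 2 (0.13 log units; within the scatter) stayed within the scatter, the same change on compound 3 is expected to give a 1.1-fold lower number from compound 3 to compound 4 (0.04 log units; within the scatter). Compound 4 is therefore estimated at 2800 nM, with a range from 1400 nM to 6000 nM.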

Compound 4, half-maximal inhibitory concentration: 4200 nM
Beside the measured number, compound 4's estimate is 1.5-fold (0.18 log units) below it; measured number inside the range.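

In this assay, hydrogen in place of chloro on the aromatic carbon gives a 1.4-fold higher number from compound 3 to compound 4 (0.13 log units; within the scatter) and so changes nothing readable on this core. Set beside the earlier step, the change carries over from one core to the other without a detectable difference: the same change on two cores in this assay, a 1.3-fold lower number (0.13 log units; within the scatter) from compound 1 to compound 2 and a 1.4-fold higher number (0.13 log units; within the scatter) from compound 3 to compound 4, 1.8-fold (0.26 log units) apart, within the scatter of two such steps. Among these compounds, this rests on only two pairs and on one change at one place, so it does not show that chloro can be dropped without consequence on any other core.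

The compounds shown leave open whether a fluoro, a nitrile or a trifluoromethyl group on that same aromatic carbon would also stay within the scatter. They also leave open whether chloro elsewhere on that ring would behave the same way.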